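Anilide series, chloro substitution on the anilide ring

A few compounds are considered here, and "the series" means these few. Any claim that something is new, unique, unknown or untested is made for them only; others in the source may bear on it.

Working notes on two measured compounds and one awaiting measurement. Compound 1 `O=C(Oc1ccc(-c2ccc(F)cc2F)cc1C(=O)O)c1ccccc1` and compound 2 `CC(=O)Oc1ccc(-c2ccc(F)cc2F)cc1C(=O)Nc1ccccc1` share a core and were both run in a functional assay on the whole organism (strain Kunming) for inhibition, with Mus musculus as the target, in the writhing test, at a dose of 40 mg/kg by the oral route; a higher number here means more inhibition at the dose given (going by the name of the read-out), a lower number less inhibition. In this assay compound 1 gives 7.97%. In this assay compound 2 gives 8.9%; this value and that of compound 1 sit within the usual scatter of each other, so no order between the two compounds can be read from the numbers, and both stand low for inhibition at this dose. Compound 3 `CC(=O)Oc1ccc(-c2ccc(F)cc2F)cc1C(=O)Nc1ccc(Cl)cc1` has not yet been measured in this assay. Compared with compound 2, compound 3 shows one difference: chloro in place of hydrogen on an aromatic carbon. Within the data shown here, no measured pair carries this same difference, so there is no measured step to rest a size on. With both measured values low and close, the expected step in this assay is a number 3.1 percentage points higher from compound 2 to compound 3 (within the scatter), that is, none beyond the scatter, with a small rise left open rather than a fall. Compound 3 is estimated at 12% in this assay, with a range from 0% to 30%.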

Compound 3, a percentage reported as inhibition, in the whole organism at one dose (the size of the read-out at that dose, not a potency): 29.9%
Compound 3: middle estimate off by 17.9 percentage points, on the low side; the range from low to high includes it.
By their numbers in this assay, from the lowest: compounds 1 and 2 (each within the scatter of the next); then compound 3.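

In this assay, among these compounds, the change from anilino to (4-chlorophenyl)amino gives a number 21 percentage points higher from compound 2 to compound 3 (beyond the scatter), the first step that can be read as a real change. It shows that this aromatic carbon, para to a large group, is not indifferent to substitution: a chloro group of 1 heavy atom, with no hydrogen-bond donor or acceptor and no net charge, is enough to move the read-out at this dose, which the two earlier values could not show. This is a size of effect at one dose rather than a potency, and no measurement at hand accounts for the rise.

Still open, on these data alone, is whether the rise is particular to chloro or would also appear with fluoro, bromo, methyl, methoxy or trifluoromethyl on the same carbon. The compounds shown also leave open whether chloro on another carbon of that ring would give a similar step, and whether the same change would hold with benzoyl or a longer acyl chain in place of the acetyl group.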